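A few compounds are considered here, and "the series" means these few. Any claim that something is new, unique, unknown or untested is made for them only; others in the source may bear on it.

Measured so far:

compound 1 `COC(=O)c1cc(=O)c2cc(NC(=O)Nc3ccc(Cl)c(Cl)c3)ccc2[nH]1` — > 6350 nM
compound 2 `COC(=O)c1cc(=O)c2cc(NC(=O)Nc3ccc(F)c(Cl)c3)ccc2[nH]1` — > 6350 nM
compound 3 `COC(=O)c1cc(=O)c2cc(NC(=O)Nc3ccc(C(F)(F)F)cc3[N+](=O)[O-])ccc2[nH]1` — 22500 nM

Compound 2 `COC(=O)c1cc(=O)c2cc(NC(=O)Nc3ccc(F)c(Cl)c3)ccc2[nH]1` stands only at a limit in a functional assay on SEM cells (Homo sapiens) for antiproliferative activity, with a stated time of 72 h; a lower number here means that less compound is needed, a higher number that more compound is needed for the effect: compound 2 gives > 6350 nM, which is a limit of the assay and not a number. Compound 1 `COC(=O)c1cc(=O)c2cc(NC(=O)Nc3ccc(Cl)c(Cl)c3)ccc2[nH]1` likewise gives > 6350 nM, again a limit. For the measured compounds named here, compound 3 `COC(=O)c1cc(=O)c2cc(NC(=O)Nc3ccc(C(F)(F)F)cc3[N+](=O)[O-])ccc2[nH]1` gives 22500 nM in this assay, the one numerical value. The step from compound 1 to compound 2 in this assay, a step that the two limits leave unreadable from compound 1 to compound 2, stays unreadable because of the limit of > 6350 nM in this assay, at which 2 of the 3 values shown sit.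

Compound 4 `COC(=O)c1cc(=O)c2cc(NC(=O)Nc3cccc(C(C)=O)c3)ccc2[nH]1` is not yet measured. It differs from compound 2 by 3-acetylphenyl in place of 3-chloro-4-fluorophenyl on an amide-type nitrogen. Going by the values given here, no measured step bears directly on this change; the only measured step, the one between compound 1 and compound 2, cannot be sized. All three compounds shown sit at or beyond the limit, so a weak value is expected for compound 4 as well, with the step from compound 2 to compound 4 expected as a step that the limit leaves unreadable from compound 2 to compound 4. Compound 4 is estimated at 15000 nM in this assay, within a range of 5000 nM to 45000 nM, with a fair chance that only a limit is reported.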

Compound 4, half-maximal effective concentration: > 8080 nM
Compound 4: only a limit was reported; the forecaster's own chance of this, stated with the estimate: 50%; the middle value is on the limit's open side.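

In this assay compound 4 gives > 8080 nM, a limit and not a number. The steps to compound 4 from compound 1 and compound 2 cannot be read because they end at limits: the limit of > 8080 nM in this assay, at which 1 of the 4 values shown sits.

The compounds shown leave open where compound 1, compound 2 and compound 4 actually stand relative to compound 3.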